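Quinolinone hydrazones: exchanging the anilino group for hydroxyethyl

The compounds below may be only part of what the source reports. "The series", "measured", "known", "first", "only" and "open" are said of these compounds alone.

Compound 1 `Cc1ccc2[nH]c(=O)c(/C=N/Nc3ccccc3)cc2c1` gives 8470 nM in a functional assay, read by spectrophotometry, with a stated time of 3 min; a higher number here means a weaker inhibitor, a lower number a stronger inhibitor. Its number stands second highest of the three measured, though all three lie within the scatter of one another. Compound 3 `Cc1ccc2[nH]c(=O)c(/C=N/Nc3ccc([N+](=O)[O-])cc3)cc2c1` gives 8250 nM in this assay, and the step of a 1.0-fold lower number from compound 1 to compound 3 (0.01 log units; within the scatter). Compound 2 `O=c1[nH]c2ccccc2cc1/C=N/Nc1ccccc1` gives 11800 nM, the step of a 1.4-fold higher number from compound 1 to compound 2 (0.14 log units; within the scatter).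

Compound 4 `Cc1ccc2[nH]c(=O)c(/C=N/CCO)cc2c1` differs from compound 1 in one place: 2-hydroxyethyl in place of anilino on a double-bonded nitrogen. Neither measured step bears directly on this change; both alter a substituent on an aromatic carbon and leave the anilino group intact, and both fall within the scatter. The change to compound 4 removes that group altogether and is larger than anything measured here, so the flatness seen so far gives only weak guidance. A step beyond the scatter is expected, more likely toward a higher number, with a wide range; the expected step is a 1.9-fold higher number from compound 1 to compound 4 (0.28 log units; within the scatter). Compound 4 is estimated at 16000 nM, within 5000 nM to 50000 nM.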

Compound 4, half-maximal inhibitory concentration: 1190000 nM
Compound 4: middle estimate off by 74-fold (1.87 log units), on the low side; the whole stated range lies below it.
By their numbers in this assay, from the lowest: compounds 3, 1 and 2 (each within the scatter of the next); then compound 4.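

The anilino group on the double-bonded nitrogen matters far more in this assay than the substituents changed on aromatic carbons (a 140-fold higher number from compound 1 to compound 4 (2.15 log units; beyond the scatter)), whereas the steps to compound 2 and compound 3 stayed within the scatter. This position is therefore sensitive in a way the earlier flat steps gave no sign of, and 2-hydroxyethyl does not stand in for anilino, even though the two groups match in hydrogen-bond donor and acceptor counts. Nothing measured here explains the size of this step, so it cannot be assigned to the lost ring or to the entering chain.

Cyclohexylamino would test whether a ring without aromatic carbons keeps the number near that of compound 1 (8470 nM). Benzylamino, a longer chain, or 2-methoxyethyl would show how much of the step depends on the aromatic ring, the chain length, or the hydroxyl.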